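The source may report more compounds than this note shows. Statements on the series, on what has been measured and on what is new or still open speak of the compounds shown alone.

Compound 1, `CC(C)OC(=O)N1CCC(Oc2ncnc3c2CCN3c2ccc(C#N)cc2F)CC1`, in a functional assay on CHO-K1 cells for agonist activity at Glucose-dependent insulinotropic receptor (Homo sapiens), read by a luciferase reporter, with a stated time of 5 h (on this read-out higher numbers stand for an effect only at larger amounts of compound and lower numbers for an effect already at smaller amounts), gives 63.1 nM.
Compound 2, `CC(C)OC(=O)N1CCC(Oc2ncnc3c2CCN3c2ccc(F)cn2)CC1`, in this assay gives only a limit of the assay and not a number, > 10000 nM.

Compound 2 therefore stands at the weaker end of the two results shown, sitting at the limit (the limit of > 10000 nM in this assay, at which 1 of the 2 values shown sits), while compound 1 gives a number. For the measured compounds named here, the only measured step, an at least 150-fold higher number from compound 1 to compound 2 (2.19 log units; beyond the scatter), lies beyond the scatter. Compound 3, `CC(C)OC(=O)N1CCC(Oc2ncnc3c2CCN3c2ccc(C#N)c(F)c2)CC1`, is not yet measured; it differs from compound 2 by 4-cyano-3-fluorophenyl in place of 5-fluoropyridin-2-yl on a nitrogen on an aromatic ring in a ring. This change runs counter to the measured one: the group leaving compound 2 is the one that entered to make it, and the entering group carries the same nitrile and fluorine as the group present in compound 1, the names being 4-cyano-3-fluorophenyl against 4-cyano-2-fluorophenyl. Because the step of an at least 150-fold higher number from compound 1 to compound 2 (2.19 log units; beyond the scatter) was large, a large step in the opposite direction in this assay is expected, an at least 66-fold lower number from compound 2 to compound 3 (1.82 log units; beyond the scatter). As compound 2 gives only a limit, the true size of that step is open. Compound 3 is estimated at 150 nM, within a range from 40 nM to 1500 nM.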

Compound 3, half-maximal effective concentration: 398 nM
Beside the measured number, compound 3's estimate is 2.7-fold (0.42 log units) below it, and the stated range covers the measured number.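

Compound 3 shows that the loss seen with 5-fluoropyridin-2-yl is not fixed by the shared core, since a different group on a nitrogen on an aromatic ring in a ring gives a measurable result again in this assay, with an at least 25-fold lower number from compound 2 to compound 3 (1.40 log units; beyond the scatter). It also shows that the two groups carrying a nitrile and a fluorine are not interchangeable at this place: 4-cyano-3-fluorophenyl in place of 4-cyano-2-fluorophenyl gives a 6.3-fold higher number from compound 1 to compound 3 (0.80 log units; beyond the scatter), a modest step that still lies beyond the scatter. Compound 2 gives only a limit and not a number, so any step that starts from it marks a bound and not a true size: the limit of > 10000 nM in this assay, at which 1 of the 3 values shown sits.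

The compounds shown leave open what the nitrile, the fluorine and the ring nitrogen each contribute, as 5-fluoropyridin-2-yl differs from both phenyl groups in all of these at once. As far as these compounds go, a 4-cyanophenyl group without fluorine, or a pyridin-2-yl group carrying a nitrile, would separate these contributions, and the response of this place to either group remains unknown here.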